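Solubility notes on the aryl replacement leading to compound 4

The source may hold more compounds than are shown below. What is called first, only, known or untested is meant among the compounds shown, and "the series" means these compounds.

Measured compounds in a physicochemical assay for solubility, read by HPLC, in simulated intestinal fluid, with a stated time of 16 h, tested at 125 ug/mL; a higher number here means a more soluble compound, a lower number a less soluble compound:
compound 1, `CNC(=O)c1cc(C(=O)NC2CC2)cn(Cc2cccc(OC)c2)c1=O`, gives 582 ug/mL.
compound 2, `CNC(=O)c1cc(C(=O)NC2CC2)cn(Cc2ccc(OC)cc2)c1=O`, gives 263 ug/mL.
compound 3, `CNC(=O)c1cc(C(=O)NC2CC2)cn(Cc2cccc3cn[nH]c23)c1=O`, gives 131 ug/mL.

Compound 1 holds the highest of the three numbers in this assay; the nearest is compound 2 (a 2.2-fold lower number from compound 1 to compound 2 (0.34 log units; beyond the scatter)) and the furthest compound 3 (a 4.4-fold lower number from compound 1 to compound 3 (0.65 log units; beyond the scatter)). Compounds 2 and 3 lie within the scatter of each other (a 2.0-fold lower number from compound 2 to compound 3 (0.30 log units; within the scatter)).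

Compound 4, `CNC(=O)c1cc(C(=O)NC2CC2)cn(Cc2cccc3occc23)c1=O`, is not yet measured. It differs from compound 1 in one place: 1-benzofuran-4-yl in place of 3-methoxyphenyl on a saturated chain carbon bound to an aromatic nitrogen

Both measured steps from compound 1 bear on this change, since each replaces the 3-methoxyphenyl on the same saturated chain carbon bound to an aromatic nitrogen. The step to 1H-indazol-7-yl (a 4.4-fold lower number from compound 1 to compound 3 (0.65 log units; beyond the scatter)) is the closer analogy; the step to 4-methoxyphenyl (a 2.2-fold lower number from compound 1 to compound 2 (0.34 log units; beyond the scatter)) marks the smaller end. A modest decrease in this assay is therefore expected, lying between these two. The expected step is a 3.1-fold lower number from compound 1 to compound 4 (0.49 log units; beyond the scatter). Compound 4 is estimated at 190 ug/mL, with a range of 80 ug/mL to 420 ug/mL.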

Compound 4, solubility: 74 ug/mL
For compound 4 the middle estimate is 2.6-fold (0.41 log units) above the measured one; the whole stated range lies above it.
By their numbers in this assay, from the lowest: compounds 4, 3 and 2 (each within the scatter of the next, the first and the last beyond it); then compound 1.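

In this assay, the step to 1-benzofuran-4-yl on the saturated chain carbon bound to an aromatic nitrogen is large (a 7.9-fold lower number from compound 1 to compound 4 (0.90 log units; beyond the scatter)), so 3-methoxyphenyl stays clearly apart from this replacement. Compound 4 cannot be separated from the 1H-indazol-7-yl compound (a 1.8-fold lower number from compound 3 to compound 4 (0.25 log units; within the scatter)), so these two groups give equivalent readings here. Unlike compound 3, which lay within the scatter of compound 2, compound 4 separates from the 4-methoxyphenyl compound (a 3.6-fold lower number from compound 2 to compound 4 (0.55 log units; beyond the scatter)), although compounds 3 and 4 themselves cannot be told apart.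

Going by these compounds, whether an aryl group carrying a dimethylamino group or a carboxylic acid at this place would bring the number back towards that of compound 1 remains open. Nothing shown here explains the size of these steps.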